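The source may report more compounds than this note shows. Statements on the series, on what has been measured and on what is new or still open speak of the compounds shown alone.

Working notes on the series. Compound 3 `COc1cc(OC)nc(NC(=S)NC(=O)c2c(-c3ccc(Cl)cc3Cl)noc2C)n1` and compound 1 `COc1cc(Cl)nc(NC(=S)NC(=O)c2c(-c3ccc(Cl)cc3Cl)noc2C)n1` carry the open thiourea linkage; compound 2 `COc1cc(OC)n2s/c(=N\C(=O)c3c(-c4ccc(Cl)cc4Cl)noc3C)nc2n1` and compound 4 `COc1cc(Cl)nc2n/c(=N/C(=O)c3c(-c4ccc(Cl)cc4Cl)noc3C)sn12` carry the fused core. In a functional assay on the whole organism for inhibition, with Digitaria ciliaris as the target, with a stated time of 72 h, tested at 10 mg/L (a higher number here means more inhibition of growth at the concentration tested, a lower number less inhibition of growth), compound 3 gives 32%, and compound 1 gives 14.6%. Among the measured compounds shown here, the single change between these two is chloro in place of methoxy on an aromatic carbon and the measured step is a number 17.4 percentage points lower from compound 3 to compound 1 (beyond the scatter). In this assay compound 2 gives 53.8%, the highest of the three numbers, with its steps to compound 3 and to compound 1 both beyond the scatter. The difference between the core of compound 2 and the core of compound 3 is not broken down here.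

Compound 4 is yet to be measured in this assay. It differs from compound 2 by chloro in place of methoxy on an aromatic carbon. The place agrees with the earlier change in lying next to the ring nitrogen, meta to a methoxy group and opposite the ring nitrogen; it differs in that the ring is part of a fused or bridged system of two rings, the carbon being meta to a fused ring and para to a fused ring, where the earlier change stood meta to a large group. The change is therefore the same kind of change, not the same.

For the measured compounds named here, only one earlier instance of this change exists, so the expectation rests on it alone. Compound 4 is expected to move by a number 17.8 percentage points lower from compound 2 to compound 4 (beyond the scatter) from compound 2, an estimate taken because the step of a number 17.4 percentage points lower from compound 3 to compound 1 (beyond the scatter) on the open core was of modest size and beyond the scatter. Compound 4 is thus estimated at 36%, with a likely range from 22% to 50%.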

Compound 4, percent growth inhibition at one concentration: 16.5%
The estimate for compound 4 lay 19.5 percentage points above the measured number, outside the stated range (below it).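

In this assay, chloro in place of methoxy lowers growth inhibition on both cores, and on the fused core the step is a number 37.3 percentage points lower from compound 2 to compound 4 (beyond the scatter), but the two steps differ in size: the same change on two cores in this assay, a number 17.4 percentage points lower (beyond the scatter) from compound 3 to compound 1 and a number 37.3 percentage points lower (beyond the scatter) from compound 2 to compound 4, 19.9 percentage points apart, beyond the scatter of two such steps

Within these two pairs, the direction of the change carries from one core to the other while its size does not, so a step read on the core of compound 3 cannot be used as a number for the core of compound 2. These two pairs do not show why the size differs, whether the same direction would hold on any further core, or whether the gap would persist at another concentration or in another species.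

Among the compounds shown, this place on the ring holds only methoxy or chloro, and everything outside the core and this place stays the same across all four. On these data alone, how an amine, a fluoro group or a longer alkoxy chain at this place would read on either core stays open, as does whether such groups would also give steps of different size on the two cores.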